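Carbamoyl on the amine nitrogen: step to compound 4

The source may hold more compounds than are shown below. What is called first, only, known or untested is meant among the compounds shown, and "the series" means these compounds.

In a functional assay on HEL cells (Homo sapiens) (a lower number here means that less compound is tolerated, a higher number that more compound is tolerated), compound 3 `COC(=O)CNC1=CS(=O)(=O)O[C@@]12[C@@H](CO[Si](C)(C)C(C)(C)C)O[C@@H](n1cc(C)c(=O)n(C)c1=O)[C@@H]2O[Si](C)(C)C(C)(C)C` gives 160000 nM, level with compound 1 `Cc1cn([C@@H]2O[C@H](CO[Si](C)(C)C(C)(C)C)[C@@]3(OS(=O)(=O)C=C3NCC(=O)O)[C@H]2O[Si](C)(C)C(C)(C)C)c(=O)n(C)c1=O` at 136000 nM. Compound 2 `CCOC(=O)NC(=O)NC1=CS(=O)(=O)O[C@@]12[C@@H](CO[Si](C)(C)C(C)(C)C)O[C@@H](n1cc(C)c(=O)n(C)c1=O)[C@@H]2O[Si](C)(C)C(C)(C)C` gives 14000 nM, clearly under both. Compound 4 `CCOC(=O)CNC(=O)NC1=CS(=O)(=O)O[C@@]12[C@@H](CO[Si](C)(C)C(C)(C)C)O[C@@H](n1cc(C)c(=O)n(C)c1=O)[C@@H]2O[Si](C)(C)C(C)(C)C` is still unmeasured, and its difference from compound 3 is ((ethoxycarbonyl)methyl)carbamoyl in place of (methoxycarbonyl)methyl on an amine nitrogen. Among the compounds with values here, two steps bear on this change, a 9.7-fold lower number from compound 1 to compound 2 (0.99 log units; beyond the scatter) and an 11-fold higher number from compound 2 to compound 3 (1.06 log units; beyond the scatter), both beyond the scatter and both involving a carbamoyl group on that amine nitrogen. The ester change in a 1.2-fold higher number from compound 1 to compound 3 (0.07 log units; within the scatter) stays within the scatter. A lower number is therefore expected, probably by somewhat less than those two steps, and the estimated move is a 6.4-fold lower number from compound 3 to compound 4 (0.81 log units; beyond the scatter). The estimate for compound 4 is 25000 nM, with an expected range of 10000 nM to 70000 nM.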

Compound 4, half-maximal cytotoxic concentration: 13000 nM
The estimate for compound 4 lay 1.9-fold (0.28 log units) above the measured number; the measured number falls inside the stated range.
By their numbers in this assay, from the lowest: compounds 4 and 2 (each within the scatter of the next); then compounds 1 and 3 (each within the scatter of the next).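

In this assay, ((ethoxycarbonyl)methyl)carbamoyl on the amine nitrogen goes with a lower number against both non-carbamoyl compounds (a 12-fold lower number from compound 3 to compound 4 (1.09 log units; beyond the scatter); a 10-fold lower number from compound 1 to compound 4 (1.02 log units; beyond the scatter)). Changing what the carbamoyl group carries makes no readable difference (a 1.1-fold lower number from compound 2 to compound 4 (0.03 log units; within the scatter)), so the lower number is shared by both carbamoyl compounds, whichever of these two groups is attached. No measured evidence on the cause of this drop is available.

Going by these compounds, whether a plain carbamoyl group on the amine nitrogen gives the same lower number remains open. So does the outcome of a carboxylic acid in place of the ethyl ester of compound 4.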